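Shifting two chlorines around a terminal phenyl ring

The source may report more compounds than this note shows. Statements on the series, on what has been measured and on what is new or still open speak of the compounds shown alone.

Compound 1 `O=C(/C=C/c1cc([N+](=O)[O-])ccc1Cl)/C=C/c1ccccc1Oc1ncnc2ccc(Cl)cc12`: 2510 nM
Compound 2 `O=C(/C=C/c1ccc(Cl)c(Cl)c1)/C=C/c1ccccc1Oc1ncnc2ccc(Cl)cc12`: 18300 nM

In a functional assay on PC-3 cells (Homo sapiens) for inhibition, read by MTT assay, with a stated time of 72 h (a lower number here means a stronger inhibitor, a higher number a weaker inhibitor), compound 2 gives the highest of the two numbers, with compound 1 showing a lower value by a 7.3-fold higher number from compound 1 to compound 2 (0.86 log units; beyond the scatter). Compound 3 `O=C(/C=C/c1ccccc1Oc1ncnc2ccc(Cl)cc12)/C=C/c1cccc(Cl)c1Cl` differs from compound 2 only by 2,3-dichlorophenyl in place of 3,4-dichlorophenyl on a double-bonded chain carbon bound to a double-bonded chain carbon. Within the data shown here, the one measured step at this position, a 7.3-fold higher number from compound 1 to compound 2 (0.86 log units; beyond the scatter), shows that the group here can move the number beyond the scatter, but it swapped different groups, so the direction for compound 3 is uncertain. Compound 3 is expected at 10000 nM, within 3000 nM to 40000 nM, an estimated step of a 1.8-fold lower number from compound 2 to compound 3 (0.26 log units; within the scatter).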

Compound 3, half-maximal inhibitory concentration: 8350 nM
Estimate against measurement, compound 3: 1.2-fold (0.08 log units) above, within the range that was stated.
By their numbers in this assay, from the lowest: compound 1; then compound 3; then compound 2.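

Moving the two chlorines, with the same atoms joined differently, still changes the result (a 2.2-fold lower number from compound 2 to compound 3 (0.34 log units; beyond the scatter)), so at this position the arrangement of the chlorines matters and not only which atoms are present. The 2,3-dichlorophenyl group still falls short of the 2-chloro-5-nitrophenyl group (a 3.3-fold higher number from compound 1 to compound 3 (0.52 log units; beyond the scatter)). No measured evidence accompanies either step.

On these data alone, how an amine or a carboxylic acid on this phenyl ring would compare remains open. So does the result of a longer chain in place of the ethenyl link.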